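Replacing 6-chloropyridin-2-yl with 4-isopropyl-1,3-thiazol-2-yl

This account rests on a few compounds, and the source may have more. Where it says the series, first, only, none or still open, it means among the compounds named here.

Values measured in a functional assay (blood) for inhibition, with Homo sapiens as the target; on this read-out higher numbers stand for weaker inhibition and lower numbers for stronger inhibition:
- compound 1 `CC(C)(C)Sc1c(CC(C)(C)C(=O)O)n(Cc2ccc(Cl)cc2)c2ccc(OCc3cc4ccccc4cn3)cc12`: > 3000 nM, a limit of the assay
- compound 2 `CC(C)(C)Sc1c(CC(C)(C)C(=O)O)n(Cc2ccc(Cl)cc2)c2ccc(OCc3nc4ccccc4o3)cc12`: 2500 nM
- compound 3 `CC(C)(C)Sc1c(CC(C)(C)C(=O)O)n(Cc2ccc(Cl)cc2)c2ccc(OCc3cccc(Cl)n3)cc12`: 410 nM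

Compound 3 has the lowest number of the three, and its lead is beyond the scatter on both sides: an at least 7.3-fold lower number from compound 1 to compound 3 (0.86 log units; beyond the scatter), and a 6.1-fold lower number from compound 2 to compound 3 (0.79 log units; beyond the scatter). The value of compound 1, > 3000 nM, is a limit and not a number.

Compound 4 `CC(C)c1csc(COc2ccc3c(c2)c(SC(C)(C)C)c(CC(C)(C)C(=O)O)n3Cc2ccc(Cl)cc2)n1` keeps the shared core and differs in one group: 4-isopropyl-1,3-thiazol-2-yl in place of 6-chloropyridin-2-yl on a saturated chain carbon bound to an oxygen on an aromatic ring. Going by the values given here, no measured compound carries the entering group, so the evidence is indirect. Three measured steps change the group at this same place. One of them, an at least 1.2-fold lower number from compound 1 to compound 2 (0.07 log units; that floor lies within the scatter), has a floor within the scatter. The other two both end at compound 3, so each group tried in place of 6-chloropyridin-2-yl has stood higher, as a 6.1-fold lower number from compound 2 to compound 3 (0.79 log units; beyond the scatter) shows. A modest rise in this assay is therefore expected, and the estimated change is a 2.4-fold higher number from compound 3 to compound 4 (0.39 log units; beyond the scatter). Compound 4 is estimated at 1000 nM, with an expected range of 250 nM to 3000 nM.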

Compound 4, half-maximal inhibitory concentration: > 3000 nM
Compound 4: no number, only a limit (the forecaster's own chance of this, stated with the estimate: 15%); middle value at least 3.0-fold (0.47 log units) from the limit.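

In this assay, 4-isopropyl-1,3-thiazol-2-yl, which like 6-chloropyridin-2-yl has one aromatic ring, does not keep the low number on this saturated chain carbon bound to an oxygen on an aromatic ring (an at least 7.3-fold higher number from compound 3 to compound 4 (0.86 log units; beyond the scatter)), and compound 3 stays lowest of the four compounds. The value of compound 4 (> 3000 nM) is a limit and not a number. Against 1,3-benzoxazol-2-yl the floor of the step lies within the scatter (an at least 1.2-fold higher number from compound 2 to compound 4 (0.07 log units; that floor lies within the scatter)), so compound 4 cannot be ranked against compound 2, and the step between compound 1 and compound 4 cannot be read: the limit of > 3000 nM in this assay, at which 2 of the 4 values shown sit.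

The compounds shown do not tell whether the low number of compound 3 depends on the chlorine or on the pyridine ring, since neither pyridin-2-yl without a substituent nor 6-methylpyridin-2-yl appears among them. They also leave open whether the isopropyl group matters to the result for compound 4, which 4-methyl-1,3-thiazol-2-yl or 1,3-thiazol-2-yl at this place could help to separate.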